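Branched saturated ether on the aminoquinoline core: compound 4

The compounds below may be only part of what the source reports. "The series", "measured", "known", "first", "only" and "open" are said of these compounds alone.

Compound 3 `CC(C)=CCOc1cccc2ccc(N)nc12` carries a 3-methylbut-2-en-1-yl ether on the shared core. In an assay on cells with melanin-concentrating hormone receptor 1 (Homo sapiens) as the target, read by radioligand binding (a lower number here means a stronger inhibitor, a higher number a weaker inhibitor), compound 3 gives > 2000 nM, which is a limit of the assay and not a number. Compound 1 `CC#CCCOc1cccc2ccc(N)nc12` likewise gives > 2000 nM, also a limit. Compound 2 `CCCCOc1cccc2ccc(N)nc12`, with a propyl chain in place of the unsaturated groups, gives 789 nM. The measured steps that bear here are an at least 2.5-fold higher number from compound 2 to compound 3 (0.40 log units; beyond the scatter) and an at least 2.5-fold lower number from compound 1 to compound 2 (0.40 log units; beyond the scatter), both against the unsaturated chains; the step that the two limits leave unreadable from compound 1 to compound 3 rests on two limits (the limit of > 2000 nM in this assay, at which 2 of the 3 values shown sit). Compound 4 `CC(C)C(C)Oc1cccc2ccc(N)nc12` differs from compound 3 by 1,2-dimethylpropyl in place of 3-methylbut-2-en-1-yl on an oxygen on an aromatic ring: the double bond leaves and branching enters. Among the measured compounds shown here, since the saturated compound 2 gave a readable number, the value for compound 4 is expected to be 1500 nM (range 500 nM to 5000 nM), an expected step of an at least 1.3-fold lower number from compound 3 to compound 4 (0.12 log units; that floor lies within the scatter), though branching at the oxygen-bound carbon has no measured precedent here.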

Compound 4, half-maximal inhibitory concentration: 199 nM
Estimate against measurement, compound 4: 7.5-fold (0.88 log units) above; measured number outside the range, below it.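

In this assay, a branched chain on this oxygen does better than the straight one: 1,2-dimethylpropyl in place of butyl gives a 4.0-fold lower number from compound 2 to compound 4 (0.60 log units; beyond the scatter). The gaps to the unsaturated chains are wider still, with an at least 10-fold lower number from compound 3 to compound 4 (1.00 log units; beyond the scatter) and an at least 10-fold lower number from compound 1 to compound 4 (1.00 log units; beyond the scatter). Both of these steps start from a limit, not a number: the limit of > 2000 nM in this assay, at which 2 of the 4 values shown sit. With only one branched chain shown, it stays open how far branching itself accounts for the step. An isopropyl, a cyclopentyl or a longer branched chain on the same oxygen would bear on that.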